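A few compounds are considered here, and "the series" means these few. Any claim that something is new, unique, unknown or untested is made for them only; others in the source may bear on it.

Compound 1 `CCCCn1cnc2c(Nc3cccc(Cl)c3)nc(NCOCc3ccc(/C=C/C(=O)Nc4ccccc4N)cc3)nc21` is assessed in a functional assay on HCT-116 cells (Homo sapiens) for antiproliferative activity, read by CCK-8 assay, with a stated time of 72 h, tested at 2 uM (a lower number here means a weaker effect, a higher number a stronger effect of the compound at the concentration tested), where compound 1 gives 4.76%. Compound 3 `CC(C)n1cnc2c(Nc3cccc(Cl)c3)nc(NCOCc3ccc(/C=C/C(=O)Nc4ccccc4N)cc3)nc21` carries the change (isopropyl in place of butyl on an aromatic nitrogen); in this assay compound 3 gives 18.5%, and the step of a number 13.7 percentage points higher from compound 1 to compound 3 (beyond the scatter) lies beyond the scatter. Compound 2 `CCCCn1cnc2c(NCc3ccc(C(=O)Nc4ccccc4N)cc3)nc(Cl)nc21` belongs to a different core; the difference between the core of compound 2 and the core of compound 1 is not broken down here. In this assay compound 2 gives 4.89%, which lies within the scatter of compound 1 and well under compound 3. Compound 4 `CC(C)n1cnc2c(NCc3ccc(C(=O)Nc4ccccc4N)cc3)nc(Cl)nc21` is not yet measured; it differs from compound 2 by isopropyl in place of butyl on an aromatic nitrogen, the same change as from compound 1 to compound 3, at the same place. Within the data shown here, only one instance of this change is measured, and it sits on another core, so its transfer is uncertain. Among the measured compounds shown here, the expected step of a number 9.1 percentage points higher from compound 2 to compound 4 (within the scatter) is taken somewhat smaller than the measured one, because the single measured step of a number 13.7 percentage points higher from compound 1 to compound 3 (beyond the scatter) is modest and the cores are not alike. Compound 4 is therefore expected to give 14% in this assay, with a range from 3% to 28%.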

Compound 4, a percentage reported as inhibition, at one concentration (the size of the read-out at that concentration, not a potency): 73.2%
Compound 4: the middle estimate sits 59.2 percentage points below what was measured; measured number above the stated range.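

In this assay, isopropyl in place of butyl on an aromatic nitrogen goes with a higher number on both cores, and on the core of compound 2 the result is a number 68.3 percentage points higher from compound 2 to compound 4 (beyond the scatter). The direction of the change carries from one core to the other in these two pairs, but its size does not: the same change on two cores in this assay, a number 13.7 percentage points higher (beyond the scatter) from compound 1 to compound 3 and a number 68.3 percentage points higher (beyond the scatter) from compound 2 to compound 4, 54.6 percentage points apart, beyond the scatter of two such steps Two pairs give no rule for a further core, and they do not show which of the differences between the two cores goes with the larger step.

From the compounds shown here alone, only butyl and isopropyl appear on this aromatic nitrogen, so it remains open how a cyclopropyl group, a longer chain or a chain ending in an amine would read on either core. Among these compounds, the read-out is taken at one concentration, and the data show only that compound 4 has a stronger effect than compound 2 at that concentration.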